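The source may hold more compounds than are shown below. What is called first, only, known or untested is meant among the compounds shown, and "the series" means these compounds.

Measured in an ADME assay on S9 fraction from liver (Rattus norvegicus) for metabolic stability, read by LC-MS, using NADPH, with a stated time of 30 min; on this read-out lower numbers stand for a less stable compound and higher numbers for a more stable compound:

- Compound 1 `CCCCCCCCc1ccc(OCC(=O)Cn2nnc(C)n2)cc1`: < 5%
- Compound 2 `CCCCCCCCc1ccc(OCC(=O)Cn2nnc(Cc3ccccc3)n2)cc1`: < 5%
- Compound 3 `CCCCCCCCc1ccc(OCC(=O)Cn2nnc(-c3ccc(C(=O)O)cc3)n2)cc1`: < 5%

Each of these three entries is a limit of the assay and not a number. Compound 1 therefore has no exact position on the scale, and its entry of < 5% is only a limit. The series as a whole offers one firm observation: the limit of < 5% in this assay, at which 3 of the 3 values shown sit.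

Compound 4 `CCCCCCCCc1ccc(OCC(=O)Cn2nnnc2C)cc1` is the next to be examined in this assay. It keeps the core of compound 1 and has the same atoms, joined differently: 5-methyl-1H-tetrazol-1-yl in place of 5-methyl-2H-tetrazol-2-yl on a saturated chain carbon bound to a carbonyl carbon. In words, 5-methyl-1H-tetrazol-1-yl stands in place of 5-methyl-2H-tetrazol-2-yl on a saturated chain carbon bound to a carbonyl carbon.

The measured steps give no size to build on. They are a step that the two limits leave unreadable from compound 1 to compound 2, a step that the two limits leave unreadable from compound 1 to compound 3 and a step that the two limits leave unreadable from compound 2 to compound 3. Going by the values given here, none of them is the same change as the one leading to compound 4.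

Compound 4 is expected to stay near the same limit because of the limit of < 5% in this assay, at which 3 of the 3 values shown sit. No change beyond the usual scatter is expected, and the estimated step is a step that the limit leaves unreadable from compound 1 to compound 4. For compound 4 the estimated value is 3%, with an expected range from 0% to 12%.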

Compound 4, percent of the compound remaining: 32%
For compound 4 the middle estimate is 29 percentage points below the measured one, outside the stated range (above it).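

With 5-methyl-1H-tetrazol-1-yl in place of 5-methyl-2H-tetrazol-2-yl on a saturated chain carbon bound to a carbonyl carbon, this assay shows a number at least 27 percentage points higher from compound 1 to compound 4 (beyond the scatter), even though the two compounds have the same atoms, joined differently. Going by these compounds alone, this is the first readable step, as the steps among compound 1, compound 2 and compound 3 cannot be read, and it shows that this position can change the result even when the group's atoms do not. Compound 4 is the only compound shown that has a measured number rather than a limit: the limit of < 5% in this assay, at which 3 of the 4 values shown sit.

The compounds shown do not reveal what in this change produces the difference, and benzyl and 4-carboxyphenyl appear only on the 2H-tetrazol-2-yl form, so it remains open whether either would give a similar step on the 1H-tetrazol-1-yl form. Going by these compounds, it is also open how this assay would read if an amide or an amine stood on the same saturated chain carbon bound to a carbonyl carbon in place of the tetrazolyl group.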